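Where the Fluorine Sits: One Swap Measured, One Expected

A few compounds are considered here, and "the series" means these few. Any claim that something is new, unique, unknown or untested is made for them only; others in the source may bear on it.

Compound 1, `O=C1Nc2ccccc2/C1=C/c1ccc(-c2cn(-c3cccc(F)c3)nn2)cc1`: in a functional assay on MKN-45 cells (Homo sapiens) for inhibition, read by CCK-8 assay, with a stated time of 24 h (a higher number here means a weaker inhibitor, a lower number a stronger inhibitor), compound 1 gives only a limit of the assay, > 20000 nM.
Compound 2, `O=C1Nc2ccccc2/C1=C/c1ccc(-c2cn(-c3ccc(F)cc3)nn2)cc1`: in this assay compound 2 gives 16700 nM.
Compound 3, `O=C1Nc2ccc(F)cc2/C1=C/c1ccc(-c2cn(-c3cccc(F)c3)nn2)cc1`: in this assay compound 3 gives 8190 nM.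

Compound 4, `O=C1Nc2ccc(F)cc2/C1=C/c1ccc(-c2cn(-c3ccc(F)cc3)nn2)cc1`, has not yet been measured. It differs from compound 3 in a single place: 4-fluorophenyl in place of 3-fluorophenyl on an aromatic nitrogen. This same change has already been made once, from compound 1 to compound 2: 4-fluorophenyl in place of 3-fluorophenyl on an aromatic nitrogen. The surroundings of the change are the same in both pairs word for word, so the change is the same, not merely of the same kind. The measured step for it was an at least 1.1-fold lower number from compound 1 to compound 2 (0.07 log units; that floor lies within the scatter); it is known only as a floor because compound 1 sits at the limit of > 20000 nM in this assay, at which 1 of the 3 values shown sits.

The two cores differ as follows: fluoro in place of hydrogen on an aromatic carbon. That change on its own gave an at least 2.4-fold lower number from compound 1 to compound 3 (0.38 log units; beyond the scatter). Of the two values that are numbers, compound 3 has the lower, and compound 2 is nearest to it.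

For the move from compound 3 to compound 4 a step of a 1.4-fold lower number from compound 3 to compound 4 (0.14 log units; within the scatter) is expected. Going by the values given here, this rests on the earlier step of an at least 1.1-fold lower number from compound 1 to compound 2 (0.07 log units; that floor lies within the scatter), which is the only measurement of this change, and on compound 3 standing at 8190 nM, a number rather than a limit, so a small move should now be readable. For compound 4 a value of 6000 nM is expected, between 3000 nM and 12000 nM.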

Compound 4, half-maximal inhibitory concentration: > 20000 nM
Compound 4: no number, only a limit; the forecaster's own chance of this, stated with the estimate: 3%; middle value at least 3.3-fold (0.52 log units) from the limit.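

In this assay, the swap of 3-fluorophenyl for 4-fluorophenyl on the core with the added fluoro gave an at least 2.4-fold higher number from compound 3 to compound 4 (0.38 log units; beyond the scatter), so the swap does not carry over unchanged from the core of compound 1: the same change on two cores in this assay, an at least 1.1-fold lower number (0.07 log units; that floor lies within the scatter) from compound 1 to compound 2 and an at least 2.4-fold higher number (0.38 log units; beyond the scatter) from compound 3 to compound 4, at least 2.9-fold (0.46 log units) apart, beyond the scatter of two such steps
The added fluoro on the core also behaved differently depending on the group on the aromatic nitrogen, and with 4-fluorophenyl in place it gave an at least 1.1-fold higher number from compound 2 to compound 4 (0.07 log units; that floor lies within the scatter), a step that does not match the one seen with 3-fluorophenyl: the same change on two cores in this assay, an at least 2.4-fold lower number (0.38 log units; beyond the scatter) from compound 1 to compound 3 and an at least 1.1-fold higher number (0.07 log units; that floor lies within the scatter) from compound 2 to compound 4, at least 2.9-fold (0.46 log units) apart, beyond the scatter of two such steps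
So in these four compounds the two changes do not simply add up, and the better number belongs to the pairing of the added fluoro with 3-fluorophenyl, but the true size of each of these steps stays unknown, and compound 1 and compound 4 cannot be ranked against each other, as each has a limit rather than a number: the limit of > 20000 nM in this assay, at which 2 of the 4 values shown sit.

What the compounds shown leave open is whether this dependence on the core holds for anything other than a fluorine on the phenyl ring, such as a chloro group, a methoxy group or an amine. As far as these compounds go, it is also open whether a plain phenyl group would sit closer to 3-fluorophenyl or to 4-fluorophenyl on either core.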